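A few compounds are considered here, and "the series" means these few. Any claim that something is new, unique, unknown or untested is made for them only; others in the source may bear on it.

In a functional assay on U-87MG ATCC cells (Homo sapiens) for cytotoxicity, with a stated time of 7 days (a lower number here means a stronger inhibitor, a higher number a weaker inhibitor), compound 1 `CC(C)=CCC/C(C)=C/CC/C(C)=C/CSc1ccccc1C(=O)OC(C)C` gives 52000 nM and compound 2 `COC(=O)c1ccccc1SC/C=C(\C)CC/C=C(\C)CCC=C(C)C` gives 10000 nM as the lower of the two numbers. Compound 3 `CC(C)=CCC/C(C)=C/CC/C(C)=C/CSc1ccccc1C(=O)OCc1ccccc1` differs from compound 2 by phenyl in place of hydrogen on a saturated chain carbon bound to an oxygen next to a carbonyl group and so reads as methyl to benzyl on the oxygen next to the carbonyl group. Among the measured compounds shown here, one measured step bears on this change: a 5.2-fold lower number from compound 1 to compound 2 (0.72 log units; beyond the scatter) at that same oxygen, with isopropyl carrying the higher number. A step of similar size toward a higher number is therefore expected in this assay and is estimated as a 3.0-fold higher number from compound 2 to compound 3 (0.48 log units; beyond the scatter) for this change. For compound 3 the expected value is 30000 nM within an estimated range of 10000 nM to 90000 nM in this series.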

Compound 3, half-maximal inhibitory concentration: 30000 nM
The estimate for compound 3 equals the measured number at the digits printed; the range from low to high includes it.
By their numbers in this assay, from the lowest: compound 2; then compounds 3 and 1 (each within the scatter of the next).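

Methyl to benzyl on the oxygen next to a carbonyl group gives a 3.0-fold higher number from compound 2 to compound 3 (0.48 log units; beyond the scatter) in this assay, so methyl now holds the lowest number against two other groups at this position. Benzyl in place of isopropyl gives a 1.7-fold lower number from compound 1 to compound 3 (0.24 log units; within the scatter), so these two groups are not separated here. The data available offer no explanation for these differences. Still open, going by these compounds, is how a longer straight chain on this oxygen would read, and whether a carboxylic acid or an amide at this carbonyl group would lower the number further.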